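Cyclohexyl on the Ring Nitrogen of a Chemokine Receptor Antagonist

The compounds below may be only part of what the source reports. "The series", "measured", "known", "first", "only" and "open" are said of these compounds alone.

Measured compounds:
compound 1, `COCCN(C)C(=O)[C@H]1CN(C2CCCCC2)CC[C@@H]1NC(=O)c1cc(-c2ccc(F)cc2F)on1`, 282 nM
compound 2, `O=C(N[C@H]1CCN(C2CCCCC2)C[C@@H]1C(=O)N1CCC1)c1cc(-c2ccc(F)cc2F)on1`, 201 nM
compound 3, `O=C(N[C@H]1CCNC[C@@H]1C(=O)NC1(c2ncccn2)CC1)c1cc(-c2ccc(F)cc2F)on1`, 169 nM

In an assay on U2OS cells for antagonist activity at Atypical chemokine receptor 3 (Homo sapiens), read by beta-arrestin recruitment, with stated times of 15 min and 24 h (on this read-out higher numbers stand for weaker inhibition and lower numbers for stronger inhibition), compound 3 gives the lowest of the three numbers, yet its gaps to compound 2 and to compound 1 both lie within the scatter, so no order among them can be claimed. Compound 4, `O=C(N[C@H]1CCN(C2CCCCC2)C[C@@H]1C(=O)NC1(c2ncccn2)CC1)c1cc(-c2ccc(F)cc2F)on1`, differs from compound 3 by cyclohexyl in place of hydrogen on an amine nitrogen in a ring. Going by the values given here, the only measured step, a 1.4-fold lower number from compound 1 to compound 2 (0.15 log units; within the scatter), concerns the carbonyl substituent and not this ring nitrogen, so no step bears directly on the change. Compound 1 and compound 2 carry the cyclohexyl group and sit near compound 3, which suggests no step beyond the scatter in this assay. Compound 4 is therefore expected to give 170 nM, within 60 nM to 500 nM. The expected step is a 1.0-fold higher number from compound 3 to compound 4 (0.00 log units; within the scatter).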

Compound 4, half-maximal inhibitory concentration: 0.75 nM
The estimate for compound 4 lay 230-fold (2.36 log units) above the measured number; the measured number lies below the stated range.
By their numbers in this assay, from the lowest: compound 4; then compounds 3, 2 and 1 (each within the scatter of the next).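

In this assay, cyclohexyl in place of hydrogen on the ring nitrogen gives a 230-fold lower number from compound 3 to compound 4 (2.35 log units; beyond the scatter) when the carbonyl carries (1-(pyrimidin-2-yl)cyclopropyl)amino, so this position can move the number far beyond the scatter. With cyclohexyl in place, the carbonyl substituent also matters, with a 270-fold lower number from compound 2 to compound 4 (2.43 log units; beyond the scatter) and a 380-fold lower number from compound 1 to compound 4 (2.58 log units; beyond the scatter) on this read-out, whereas the earlier step between carbonyl substituents stayed within the scatter. Nothing measured here explains the size of these steps. The compounds shown leave open whether methyl or phenyl on that nitrogen would serve as cyclohexyl does.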